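The source may report more compounds than this note shows. Statements on the series, on what has been measured and on what is new or still open speak of the compounds shown alone.

Working notes on the series, all read in a functional assay (trachea) with Cavia porcellus as the target; on this read-out lower numbers stand for an effect already at smaller amounts and higher numbers for an effect only at larger amounts of compound. Compound 1 `CCCn1c(=O)n(CC(=O)O)c(=O)c2[nH]cnc21` gives 41000 nM and compound 2 `CCCn1c(=O)n(CCC(=O)O)c(=O)c2[nH]cnc21` gives 21200 nM on the shared core. These two cannot be separated, as a 1.9-fold lower number from compound 1 to compound 2 (0.29 log units; within the scatter) shows, so compound 2 sits level with compound 1 at the high end of the numbers shown. Compound 3 `CCCn1c(=O)n(CCC#N)c(=O)c2[nH]cnc21` gives the lowest number of the three (1700 nM), with a 24-fold lower number from compound 1 to compound 3 (1.38 log units; beyond the scatter) and a 12-fold lower number from compound 2 to compound 3 (1.10 log units; beyond the scatter) as its two large steps.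

Next comes compound 4 `CCCn1c(=O)n(CCCN(C)C)c(=O)c2[nH]cnc21`, not yet measured. The change from compound 2 is (dimethylamino)methyl in place of carboxy on a saturated chain carbon, two bonds along the chain from an aromatic nitrogen and, cut one bond further out, reads 2-carboxyethyl to 3-(dimethylamino)propyl. The nearest measured precedent is a 12-fold lower number from compound 2 to compound 3 (1.10 log units; beyond the scatter) where carboxy also leaves at the same place, but a different group enters there. The one measured chain extension, a 1.9-fold lower number from compound 1 to compound 2 (0.29 log units; within the scatter) stayed within the scatter, so chain length alone offers little guidance. For the measured compounds named here, no measured compound carries the (dimethylamino)methyl group, so only part of the large step is carried over, in the same downward direction. The expected change is a 2.7-fold lower number from compound 2 to compound 4 (0.42 log units; beyond the scatter) and this estimate is deliberately loose. For compound 4 the estimated value is 8000 nM with an expected range of 2000 nM to 30000 nM (the upper end reaching the level of compound 2).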

Compound 4, half-maximal effective concentration: 20500 nM
For compound 4 the middle estimate is 2.6-fold (0.41 log units) below the measured one, within the range that was stated.
By their numbers in this assay, from the lowest: compound 3; then compounds 4, 2 and 1 (each within the scatter of the next).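

In this assay, (dimethylamino)methyl in place of carboxy on a saturated chain carbon, two bonds along the chain from an aromatic nitrogen, leaves the read-out level (a 1.0-fold lower number from compound 2 to compound 4 (0.01 log units; within the scatter)), and the comparison with the shorter acid gives the same picture (a 2.0-fold lower number from compound 1 to compound 4 (0.30 log units; within the scatter)). Losing carboxy at this place is therefore not enough to bring the number down, since the large earlier step appears only with the nitrile of compound 3, which stands apart from the amine as well (a 12-fold higher number from compound 3 to compound 4 (1.08 log units; beyond the scatter)). So far, the series separates compound 3 from compounds 1, 2 and 4 rather than acids from non-acids, and nothing available explains why the nitrile stands apart while the amine does not.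

The compounds shown leave open whether the nitrile keeps its low number on a shorter or longer chain, and whether a primary amine or a primary amide at the same place would sit with compound 3 or with compound 4. They also leave open whether a longer alkyl chain in place of the propyl group on the shared core would change these steps.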